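This account rests on a few compounds, and the source may have more. Where it says the series, first, only, none or still open, it means among the compounds named here.

Measured compounds:
compound 1, `CCn1c(C(=O)N[C@H](C)C(=O)OC)ccc1C(CC)(CC)c1ccc(OCS(=O)(=O)c2ccccc2)c(C)c1` — > 50000 nM in a functional assay on PC-3 cells (Homo sapiens) for antiproliferative activity, read by MTT assay, with a stated time of 24 h (a lower number here means a stronger inhibitor, a higher number a weaker inhibitor), a limit of the assay rather than a number.
compound 2, `CCn1c(C(=O)N[C@H](C)CO)ccc1C(CC)(CC)c1ccc(OCS(=O)(=O)c2ccccc2)c(C)c1` — 7790 nM in this assay.

Compound 2 therefore holds the only number shown; the other entry is a limit (the limit of > 50000 nM in this assay, at which 1 of the 2 values shown sits). Among the compounds with values here, the single measured step, an at least 6.4-fold lower number from compound 1 to compound 2 (0.80 log units; beyond the scatter), shows that replacing the methoxycarbonyl with a hydroxymethyl on the chain carbon bound to the amide-type nitrogen lowered the number at least modestly. Compound 3, `CCn1c(C(=O)N[C@@H](CO)CCCO)ccc1C(CC)(CC)c1ccc(OCS(=O)(=O)c2ccccc2)c(C)c1`, differs from compound 2 by 2-hydroxyethyl in place of hydrogen on a saturated chain carbon, two bonds along the chain from an amide-type nitrogen. The measured step concerns a change of group on the chain, not an added 2-hydroxyethyl, so it bears on the new step only loosely, and no step near this one is shown. A small change in either direction is expected, likely within the scatter. Compound 3 is therefore estimated at 6500 nM, between 2500 nM and 20000 nM, which means an expected step of a 1.2-fold lower number from compound 2 to compound 3 (0.08 log units; within the scatter).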

Compound 3, half-maximal inhibitory concentration: 13400 nM
The estimate for compound 3 lay 2.1-fold (0.31 log units) below the measured number, within the range that was stated.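

In this assay, the saturated chain carbon two bonds along the chain from the amide-type nitrogen takes 2-hydroxyethyl in place of hydrogen with a 1.7-fold higher number from compound 2 to compound 3 (0.24 log units; within the scatter), so this added group moves the reading by no more than the scatter. Set against the methoxycarbonyl side chain, this longer side chain still gives an at least 3.7-fold lower number from compound 1 to compound 3 (0.57 log units; beyond the scatter), so the step beyond the scatter seen with hydroxymethyl alone is also seen with the added 2-hydroxyethyl. Compound 1 stands only as a limit of the assay, not as a number: the limit of > 50000 nM in this assay, at which 1 of the 3 values shown sits.

The compounds shown leave open whether an amine or a carboxylic acid at the end of this chain, or a longer chain, would give a step beyond the scatter. They also leave open whether a plain propyl here would read like the 3-hydroxypropyl.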